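Side-chain removal repeated on a second core

The compounds below may be only part of what the source reports. "The series", "measured", "known", "first", "only" and "open" are said of these compounds alone.

In an assay on isolated protein for inhibition of protein deacetylase HDAC6 (Homo sapiens), read by fluorescence, with a stated time of 30 min (on this read-out higher numbers stand for weaker inhibition and lower numbers for stronger inhibition), the measured compounds stand as follows:
compound 1 `COc1cc2c(NCC3CCC(C(=O)NO)CC3)cc(-c3ccc(C)o3)nc2cc1OCCCN1CCCC1` gives 34 nM;
compound 3 `COc1cc2nc(-c3ccc(C)o3)cc(NCC3CCC(C(=O)NO)CC3)c2cc1OC` gives 41 nM;
compound 2 `COc1cc2c(NCC3CCN(c4ncc(C(=O)NO)cn4)CC3)cc(C)nc2cc1OCCCN1CCCC1` gives 350 nM.

Compound 1 and compound 3 differ in one place: hydrogen in place of 2-(pyrrolidin-1-yl)ethyl on a saturated chain carbon bound to an oxygen on an aromatic ring. The step is a 1.2-fold higher number from compound 1 to compound 3 (0.08 log units; within the scatter), so the two numbers cannot be ordered against each other in this assay. Compound 2 is built on a different core from compound 1; the difference between the two cores is not broken down here. Compound 2 gives the highest number of the three, and its distance from compound 3 and from compound 1 is beyond the scatter in both cases.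

Compound 4 `COc1cc2nc(C)cc(NCC3CCN(c4ncc(C(=O)NO)cn4)CC3)c2cc1OC` is not yet measured. It differs from compound 2 by hydrogen in place of 2-(pyrrolidin-1-yl)ethyl on a saturated chain carbon bound to an oxygen on an aromatic ring. The place of this change is the same, word for word, as in the pair compound 1 to compound 3, so the same change is applied here to the core of compound 2. The expectation for the step from compound 2 to compound 4 is a 1.1-fold higher number from compound 2 to compound 4 (0.06 log units; within the scatter), which rests on the step of a 1.2-fold higher number from compound 1 to compound 3 (0.08 log units; within the scatter) and on compound 2 giving 350 nM. Whether the change carries over unchanged to the second core is not shown by any measured pair, so the range is kept wider than the single known step. Compound 4 is therefore estimated at 400 nM, expected to fall between 180 nM and 900 nM.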

Compound 4, half-maximal inhibitory concentration: 253 nM
Compound 4: the middle estimate sits 1.6-fold (0.20 log units) above what was measured, within the range that was stated.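

In this assay, within the data shown here, replacing 3-(pyrrolidin-1-yl)propoxy with methoxy on the core of compound 2 gives a 1.4-fold lower number from compound 2 to compound 4 (0.14 log units; within the scatter), so on this core, as on the core of compound 1, the change leaves no step that can be told from the scatter. Set side by side, the two steps do not differ: the same change on two cores in this assay, a 1.2-fold higher number (0.08 log units; within the scatter) from compound 1 to compound 3 and a 1.4-fold lower number (0.14 log units; within the scatter) from compound 2 to compound 4, 1.7-fold (0.22 log units) apart, within the scatter of two such steps. This shows that, in these two pairs and on this read-out, the side chain can be cut back to methoxy with no step beyond the scatter, but it does not show that the same holds on any other core or in any other assay, and two pairs are too few to make this a rule for the series.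

What the compounds shown leave open is whether the result belongs to the 2-(pyrrolidin-1-yl)ethyl group alone or extends to other groups at the same place, such as a dimethylamino group or a carboxylic acid at the end of a longer chain. Also open, from the compounds shown here alone, is whether a free hydroxyl group in place of the methoxy would give a step of similar size on either core.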